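Chloro substitution on the aryl ring: tolerability notes

The compounds below may be only part of what the source reports. "The series", "measured", "known", "first", "only" and "open" are said of these compounds alone.

Measured compounds:
- Compound 1 `Nc1c(C2=NCCN2)cnn1-c1ccccc1` gives > 500000 nM in an ADME assay on Vero cells (Chlorocebus sabaeus) for cytotoxicity, read by CellTiter-Glo and ATP content, with a stated time of 72 h; a higher number here means that more compound is tolerated, a lower number that less compound is tolerated; this is a limit of the assay, not a number.
- Compound 2 `Nc1c(C2=NCCN2)cnn1-c1ccc(Cl)cc1` gives > 500000 nM in this assay; again a limit, not a number.
- Compound 3 `Nc1c(C2=NCCCN2)cnn1-c1cccc(Cl)c1` gives > 500000 nM in this assay; again a limit, not a number.

The change chloro in place of hydrogen on an aromatic carbon produced a step that the two limits leave unreadable from compound 1 to compound 2, so its size is not readable. The difference between the core of compound 1 and the core of compound 3 is not broken down here. Compound 4 `Nc1c(C2=NCCCN2)cnn1-c1cc(Cl)cc(Cl)c1` is not yet measured; it differs from compound 3 by chloro in place of hydrogen on an aromatic carbon. This is the same kind of change as from compound 1 to compound 2, though the place differs: there the entering chloro sits para to a large group, here it sits meta to a chloro group (1 heavy atom) and meta to a large group. Within the data shown here, every value so far sits at the limit of > 500000 nM in this assay, at which 3 of the 3 values shown sit. The step from compound 3 to compound 4 is expected to be a number no higher from compound 3 to compound 4 (the limit leaves the size open), an expectation resting only on the limit of > 500000 nM in this assay, at which 3 of the 3 values shown sit, and on a step that the two limits leave unreadable from compound 1 to compound 2. Compound 4 is therefore estimated at 500000 nM in this assay, with an expected range from 200000 nM to 1000000 nM.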

Compound 4, half-maximal cytotoxic concentration: > 500000 nM
Compound 4: no number, only a limit (the forecaster's own chance of this, stated with the estimate: 75%); the middle value sits exactly at the limit.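

In this assay compound 4 gives > 500000 nM, again a limit and not a number, so no step can be read between compound 3 and compound 4; the same holds across the series: the limit of > 500000 nM in this assay, at which 4 of the 4 values shown sit. The compounds shown leave open how much of each is tolerated and whether chloro in place of hydrogen on an aromatic carbon changes that at all.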